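Swapping Chloro for Fluoro on an Inactive Triazole Scaffold

A few compounds are considered here, and "the series" means these few. Any claim that something is new, unique, unknown or untested is made for them only; others in the source may bear on it.

The series is tested in a functional assay on Jurkat cells (Homo sapiens) for antiproliferative activity, read by MTT assay, with a stated time of 72 h; a lower number here means a stronger inhibitor, a higher number a weaker inhibitor. Compound 1, `COc1cc(-n2ncnc2-c2ccc(Cl)cc2)cc(OC)c1OC`, gives in this assay only a limit, > 10000 nM, so no numerical value stands for it. Compound 2, `COc1cc(-c2ncnn2-c2ccc([N+](=O)[O-])cc2)cc(OC)c1OC`, also reaches only a limit in this assay, > 10000 nM. Compound 3, `COc1cc(-c2ncnn2-c2ccc(Cl)c(Cl)c2)cc(OC)c1OC`, likewise shows only a limit in this assay, > 10000 nM. For the measured compounds named here, all measured values thus sit at the limit of > 10000 nM in this assay, at which 3 of the 3 values shown sit, and no pairwise step between measured compounds is available. The unmeasured compound 4, `COc1cc(-n2ncnc2-c2ccc(F)cc2)cc(OC)c1OC`, differs from compound 1 by fluoro in place of chloro on an aromatic carbon. Because compound 1 stands at the limit of > 10000 nM in this assay, at which 3 of the 3 values shown sit, together with every other measured value, the step from compound 1 to compound 4 is expected to bring nothing beyond the usual scatter, with compound 4 also expected to remain at the limit. The estimated step is a step that the limit leaves unreadable from compound 1 to compound 4. For compound 4 the expected value in this assay is 20000 nM, within a range from 8000 nM to 60000 nM.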

Compound 4, half-maximal inhibitory concentration: > 10000 nM
Compound 4: no number, only a limit; the forecaster's own chance of this, stated with the estimate: 85%; the middle value does not contradict the limit.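

For the compounds shown here, compound 4, like compound 1, gives only a limit in this assay, so no step between the two can be read: the limit of > 10000 nM in this assay, at which 4 of the 4 values shown sit. The compounds shown leave open whether fluoro in place of chloro changes the activity at all, and how they rank against one another.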